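A few compounds are considered here, and "the series" means these few. Any claim that something is new, unique, unknown or untested is made for them only; others in the source may bear on it.

Measured so far:
compound 1, `CCC(/C=C1\OC(=O)NC1=O)(CC)c1ccc(-c2ccc3cc(F)cc(F)c3c2)[nH]c1=O`: > 3 h
compound 2, `CC(C)C(c1ccc(-c2ccc3cccc(F)c3c2)[nH]c1=O)C1SC(=O)NC1=O`: 1.87 h

In an ADME assay on microsomes from liver (Homo sapiens) for metabolic stability (on this read-out lower numbers stand for a shorter-lived compound and higher numbers for a longer-lived compound), compound 1 returns only a limit, > 3 h. In this assay, within the data shown here, compound 2 gives 1.87 h, which is the only number in the set. The other result, that of compound 1, is a limit, (the limit of > 3 h in this assay, at which 1 of the 2 values shown sits). No pair of measured compounds differs in a single place, so the two results can be set side by side but no measured step can be drawn from them, and nothing in this set gives a cause for either result.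

Compound 3, `CC(C)C(CC1C(=O)NC(=O)N1C)c1ccc(-c2ccc3cccc(F)c3c2)[nH]c1=O`, is still to be measured. It departs from compound 2 by one change: (3-methyl-2,5-dioxoimidazolidin-4-yl)methyl in place of 2,4-dioxo-1,3-thiazolidin-5-yl on a saturated chain carbon bound to an aromatic carbon and a saturated chain carbon. Both the leaving and the entering group are five-membered non-aromatic rings with two hetero atoms, so the change is a swap of one such ring for another, set one carbon further out from the chain.

Among the measured compounds shown here, with no measured step to lean on, the step expected in this assay is small, within the scatter, with no clear direction. Compound 3 is estimated at 2 h, with a range from 0.9 h to 4 h. The expected step is a 1.1-fold higher number from compound 2 to compound 3 (0.03 log units; within the scatter).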

Compound 3, half-life: 0.153 h
The estimate for compound 3 lay 13-fold (1.12 log units) above the measured number, and the stated range ends above it.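

In this assay, placing (3-methyl-2,5-dioxoimidazolidin-4-yl)methyl in place of 2,4-dioxo-1,3-thiazolidin-5-yl on a saturated chain carbon bound to an aromatic carbon and a saturated chain carbon gives a 12-fold lower number from compound 2 to compound 3 (1.09 log units; beyond the scatter). Among these compounds, this is the first single-place comparison, and it shows that this position is not indifferent to the choice of group: two five-membered non-aromatic rings with 2 hetero atoms do not read alike here, so ring size and hetero atom number alone do not make them interchangeable. The change bundles several differences, namely sulfur leaving the ring, a ring nitrogen carrying methyl and the ring standing one carbon further out, and the step cannot be divided among them, while nothing shown gives a cause for it.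

Which of these differences carries the step stays open, as does the reading in this assay for an unsubstituted 2,5-dioxoimidazolidin-4-yl ring or a carboxylic acid at this place. As far as these compounds go, compound 1 returns only a limit, > 3 h, and it differs from the other compounds in more than one place, so its contribution to this question remains open too.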